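A few compounds are considered here, and "the series" means these few. Any claim that something is new, unique, unknown or untested is made for them only; others in the source may bear on it.

Compound 1 `C[Se]/C(=N\C(=O)c1cc2ccccc2s1)NC(=O)c1cc2ccccc2s1`: in a functional assay on MCF7 cells (Homo sapiens) for cytotoxicity, read by MTT assay, with a stated time of 72 h (on this read-out lower numbers stand for stronger inhibition of growth and higher numbers for weaker inhibition of growth), compound 1 gives 32700 nM.
Compound 2 `CS/C(=N\C(=O)c1sccc1Cl)NC(=O)c1sccc1Cl`: in this assay compound 2 gives 57100 nM.
Compound 3 `CS/C(=N\C(=O)c1cc2ccccc2s1)NC(=O)c1cc2ccccc2s1`: in this assay compound 3 gives 43400 nM.

Compounds 3 and 1 share a core and differ in one place: a group of 2 heavy atoms (1 carbon, 1 selenium; no ring) in place of a group of 2 heavy atoms (1 carbon, 1 sulfur; no ring), on a carbon with a double bond to nitrogen. That change gave a 1.3-fold lower number from compound 3 to compound 1 (0.12 log units; within the scatter), a step that is within the scatter, so the two numbers cannot be told apart.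

Compound 4 `C[Se]/C(=N\C(=O)c1sccc1Cl)NC(=O)c1sccc1Cl` carries the same change on the core of compound 2: a group of 2 heavy atoms (1 carbon, 1 selenium; no ring) in place of a group of 2 heavy atoms (1 carbon, 1 sulfur; no ring), on a carbon with a double bond to nitrogen. How the core of compound 2 differs from that of compound 3 is not broken down here. Among the compounds with values here, since the change sits on the same kind of carbon with the same neighbours, the step from compound 2 to compound 4 is expected to be as small as the one from compound 3 to compound 1, estimated at a 1.3-fold lower number from compound 2 to compound 4 (0.10 log units; within the scatter). Compound 4 is therefore expected to give about 45000 nM in this assay, between 22000 nM and 95000 nM.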

Compound 4, concentration for total growth inhibition: 31200 nM
Compound 4: middle estimate off by 1.4-fold (0.16 log units), on the high side; measured number inside the range.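

Putting the selenium-bearing group in place of methylsulfanyl, on the carbon with a double bond to nitrogen, gave a 1.8-fold lower number from compound 2 to compound 4 (0.26 log units; within the scatter) in this assay. Set beside the earlier step, the swap reads the same on both cores: the same change on two cores in this assay, a 1.3-fold lower number (0.12 log units; within the scatter) from compound 3 to compound 1 and a 1.8-fold lower number (0.26 log units; within the scatter) from compound 2 to compound 4, 1.4-fold (0.14 log units) apart, within the scatter of two such steps. This shows that the swap left the number within the scatter on these two cores, but it does not show a real difference between the sulfur and selenium compounds, and it says nothing about other cores.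

The compounds shown leave open what a longer chain or an amine would give in place of methylsulfanyl. They also leave open how the same swap would read on a core carrying a carboxylic acid.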